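The source may report more compounds than this note shows. Statements on the series, on what has been measured and on what is new or still open speak of the compounds shown alone.

Measured compounds:
- compound 1, `CC(C)c1onc(-c2c(Cl)cccc2Cl)c1COc1ccc(-c2nc3ccc(C(=O)O)cc3n2CC(C)(C)C)cc1`; in an assay on isolated protein for agonist activity at Bile acid receptor (Homo sapiens), read by TR-FRET (on this read-out lower numbers stand for an effect already at smaller amounts and higher numbers for an effect only at larger amounts of compound), compound 1 gives 24.8 nM
- compound 2, `CC(C)c1onc(-c2c(Cl)cccc2Cl)c1COc1ccc(-c2nc3ccc(C(=O)O)cc3n2C2CC2)cc1`; compound 2 gives 117 nM
- compound 3, `CC(C)c1onc(-c2c(Cl)cccc2Cl)c1COc1ccc(-c2nc3ccc(C(=O)O)cc3n2-c2ccc(F)cc2)cc1`; compound 3 gives 15.1 nM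

Among the compounds with values here, compound 3 shows the lowest number of the three, but its gap to compound 1 lies within the scatter, so no order between those two is claimed; only the step of a 7.7-fold lower number from compound 2 to compound 3 (0.89 log units; beyond the scatter) stands beyond it.

Compound 4, `CC(C)c1onc(-c2c(Cl)cccc2Cl)c1COc1ccc(-c2nc3ccc(C(=O)O)cc3n2C(C)C)cc1`, differs from compound 3 in one place: isopropyl in place of 4-fluorophenyl on an aromatic nitrogen. Within the data shown here, three measured steps bear on this position. Exchanging the ring-bearing group for the larger chain, a 1.6-fold lower number from compound 1 to compound 3 (0.22 log units; within the scatter), changed little; exchanging it for the small ring, a 7.7-fold lower number from compound 2 to compound 3 (0.89 log units; beyond the scatter), and a 4.7-fold higher number from compound 1 to compound 2 (0.67 log units; beyond the scatter) show that the small substituents give higher numbers. Isopropyl, a short chain without a ring, is expected to sit between these cases, so a modest rise in this assay is expected, a 3.0-fold higher number from compound 3 to compound 4 (0.47 log units; beyond the scatter). Compound 4 is estimated at 45 nM, range 20 nM to 120 nM.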

Compound 4, half-maximal effective concentration: 56.7 nM
Beside the measured number, compound 4's estimate is 1.3-fold (0.10 log units) below it; low and high end bracket the measured number.
By their numbers in this assay, from the lowest: compounds 3 and 1 (each within the scatter of the next); then compound 4; then compound 2.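

In this assay, the step from cyclopropyl to isopropyl gives a 2.1-fold lower number from compound 2 to compound 4 (0.31 log units; beyond the scatter), so these two small groups on the aromatic nitrogen are told apart. Isopropyl does not reach the larger groups, with a 3.8-fold higher number from compound 3 to compound 4 (0.57 log units; beyond the scatter) and a 2.3-fold higher number from compound 1 to compound 4 (0.36 log units; beyond the scatter). No measurement here accounts for these differences.

Open, from the compounds shown here alone, is whether the 4-fluorophenyl result needs its fluorine, which unsubstituted phenyl would test. Also open, going by these compounds, is how a longer straight chain or a chain ending in an amine would rank on this nitrogen.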